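A few compounds are considered here, and "the series" means these few. Any claim that something is new, unique, unknown or untested is made for them only; others in the source may bear on it.

Compound 1 `CN(C)CCn1cnnc1-c1cc(Oc2ccc(NC(=O)N/N=C/c3c(Cl)cccc3Cl)cc2F)ccn1` carries a 2,6-dichlorophenyl group on a carbon with a double bond to nitrogen. In a functional assay on U-87MG ATCC cells (Homo sapiens) for cytotoxicity, read by MTT assay, with a stated time of 72 h (on this read-out higher numbers stand for weaker inhibition and lower numbers for stronger inhibition), compound 1 gives only a limit of the assay, > 100000 nM, so for compound 1 no number is known, only a floor (the limit of > 100000 nM in this assay, at which 1 of the 3 values shown sits). Two measured compounds differ from compound 1 only in this group. Compound 2 `COc1ccc(/C=N/NC(=O)Nc2ccc(Oc3ccnc(-c4nncn4CCN(C)C)c3)c(F)c2)c(OC)c1OC` carries a 2,3,4-trimethoxyphenyl group in that place and gives 7650 nM in this assay. Compound 3 `CN(C)CCn1cnnc1-c1cc(Oc2ccc(NC(=O)N/N=C/c3cccc(Cl)c3Cl)cc2F)ccn1` carries a 2,3-dichlorophenyl group there and gives 13200 nM in this assay. Both changes away from the 2,6-dichlorophenyl group gave lower numbers: an at least 13-fold lower number from compound 1 to compound 2 (1.11 log units; beyond the scatter) and an at least 7.5-fold lower number from compound 1 to compound 3 (0.87 log units; beyond the scatter). Between the two replacements themselves the gap is small, a 1.7-fold higher number from compound 2 to compound 3 (0.24 log units; within the scatter).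

The unmeasured compound 4 `CN(C)CCn1cnnc1-c1cc(Oc2ccc(NC(=O)N/N=C/c3ccc(F)cc3Cl)cc2F)ccn1` makes a change of the same kind: 2-chloro-4-fluorophenyl in place of 2,6-dichlorophenyl on a carbon with a double bond to nitrogen. Because the two steps of an at least 13-fold lower number from compound 1 to compound 2 (1.11 log units; beyond the scatter) and an at least 7.5-fold lower number from compound 1 to compound 3 (0.87 log units; beyond the scatter) both pointed downward from compound 1 by a large margin, a similar step is expected here. The step from compound 1 to compound 4 is estimated as an at least 6.6-fold lower number from compound 1 to compound 4 (0.82 log units; beyond the scatter). Compound 4 is therefore expected to give about 15000 nM in this assay, within a range from 5000 nM to 60000 nM.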

Compound 4, half-maximal inhibitory concentration: 1210 nM
Compound 4: the middle estimate sits 12-fold (1.09 log units) above what was measured, outside the stated range (below it).
By their numbers in this assay, from the lowest: compound 4; then compounds 2 and 3 (each within the scatter of the next). At a limit, above all of these: compound 1.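

Until now, the two replacements of the 2,6-dichlorophenyl group, in compound 2 and compound 3, lay within the scatter of each other, which left open whether the choice among replacements mattered much; in this assay, the 2-chloro-4-fluorophenyl group shows that it does, with an 11-fold lower number from compound 3 to compound 4 (1.04 log units; beyond the scatter) and a 6.3-fold lower number from compound 2 to compound 4 (0.80 log units; beyond the scatter). The step of an at least 82-fold lower number from compound 1 to compound 4 (1.91 log units; beyond the scatter) joins two groups that match in heavy-atom count and in hydrogen-bond donors and acceptors, with one chlorine giving way to one fluorine and the halogens placed differently on the ring, so a small edit at this position can shift the number widely. That step gives only a minimum because compound 1 stands at a limit: the limit of > 100000 nM in this assay, at which 1 of the 4 values shown sits.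

On these data alone, whether the fluorine or the loss of the second chlorine matters more stays open, and a plain 2-chlorophenyl or 4-fluorophenyl group on the same carbon would help to separate the two. Also open, as far as these compounds go, is how a group of a different kind in this place, such as an amine or a carboxylic acid, would read out in this assay.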